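Aryl swap on the acetylated five-membered core

The compounds below may be only part of what the source reports. "The series", "measured", "known", "first", "only" and "open" are said of these compounds alone.

Compound 1 `COc1cc(C2=NN(C(C)=O)C(c3ccccc3C(F)(F)F)O2)cc(OC)c1OC` is the acetylated five-membered core bearing a 2-(trifluoromethyl)phenyl on its saturated ring carbon. Within the data shown here, in a functional assay on PC-3 cells (Homo sapiens) for antiproliferative activity, read by MTT assay, tested at 5 uM (on this read-out lower numbers stand for a weaker effect and higher numbers for a stronger effect at the one concentration tested), compound 1 gives 15.2%, the lowest of the three numbers measured so far. The two other measured compounds carry a different linker: compound 2 `COc1cc(C(=O)N/N=C/c2c(Cl)cccc2Cl)cc(OC)c1OC` gives 52.1% in this assay, and compound 3 `COc1cc(C(=O)N/N=C/c2cc(Cl)cc(Cl)c2)cc(OC)c1OC` gives 46.3%. Among the measured compounds shown here, the only single-place step among them is a number 5.8 percentage points lower from compound 2 to compound 3 (within the scatter), so moving the two chlorines around the aryl ring on that linker left the read-out unchanged within the scatter.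

Compound 4 `COc1cc(C2=NN(C(C)=O)C(c3ccc(F)c(F)c3)O2)cc(OC)c1OC` differs from compound 1 in one place: 3,4-difluorophenyl in place of 2-(trifluoromethyl)phenyl on a saturated ring carbon

For the measured compounds named here, no measured step touches the saturated ring carbon of this core, so the step from compound 2 to compound 3 bears on the change only loosely, as a sign that repositioning halogens on the aryl ring need not move the number. Given that compound 1 sits at 15.2%, the replacement is expected to leave the read-out near its starting point, and the estimated step is a number 4.8 percentage points higher from compound 1 to compound 4 (within the scatter), which is within the scatter. Compound 4 is therefore estimated at 20% in this assay, with a range from 5% to 40%.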

Compound 4, a percentage reported as inhibition, at one concentration (the size of the read-out at that concentration, not a potency): 46.9%
Compound 4: middle estimate off by 26.9 percentage points, on the low side; the whole stated range lies below it.
By their numbers in this assay, from the lowest: compound 1; then compounds 3, 4 and 2 (each within the scatter of the next).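

In this assay, the saturated ring carbon of the shared core proves sensitive to the aryl group it carries: 3,4-difluorophenyl in place of 2-(trifluoromethyl)phenyl gives a number 31.7 percentage points higher from compound 1 to compound 4 (beyond the scatter) on this single-concentration read-out. Among these compounds, the only earlier single-place step, a number 5.8 percentage points lower from compound 2 to compound 3 (within the scatter), concerned a different linker and a shift of the chlorines, so it gave no sign that an aryl change could matter this much on the acetylated core. The swap alters both the fluorinated substituent and its place on the aryl ring, and nothing available separates these two changes or offers a reason for the step.

Open, on these data alone, is how the read-out at this carbon responds to an unsubstituted phenyl, a methoxyphenyl or a pyridine ring, any of which would show whether the 2-(trifluoromethyl)phenyl of compound 1 lowers the number or the 3,4-difluorophenyl of compound 4 raises it. Also open, as far as these compounds go, is whether the same aryl swap has a comparable effect on the linker of compound 2 and compound 3, and whether the acetyl group on the core can give way to a propanoyl group.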